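The source may report more compounds than this note shows. Statements on the series, on what has been measured and on what is new or still open speak of the compounds shown alone.

Among the measured compounds shown here, in a functional assay on NAMALVA cells (Homo sapiens) for cytotoxicity, read by MTT assay, with a stated time of 72 h (a lower number here means a stronger inhibitor, a higher number a weaker inhibitor), compound 1 (`O=C(Nc1ccc(Cl)cc1)Nc1ccc(C(=O)NO)cc1`) gives 870 nM, and compound 2 (`COc1ccc(NC(=O)Nc2ccc(C(=O)NO)cc2)cc1`) gives 4790 nM, the higher of the two numbers so far. Compound 3 (`O=C(Nc1ccc(C(=O)NO)cc1)Nc1ccc([N+](=O)[O-])cc1`) has nitro in place of methoxy on an aromatic carbon. For the measured compounds named here, only one measured step bears on this change: a 5.5-fold higher number from compound 1 to compound 2 (0.74 log units; beyond the scatter), modest and beyond the scatter, with methoxy replacing chloro. On this single step, removing methoxy is expected to lower the number by a modest amount. The expected step is a 3.2-fold lower number from compound 2 to compound 3 (0.50 log units; beyond the scatter). For compound 3 the estimate is 1500 nM, with an expected range of 500 nM to 4500 nM.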

Compound 3, half-maximal inhibitory concentration: 13300 nM
Beside the measured number, compound 3's estimate is 8.9-fold (0.95 log units) below it; measured number outside the range, above it.
By their numbers in this assay, from the lowest: compound 1; then compound 2; then compound 3.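

In this assay nitro in place of methoxy gives a 2.8-fold higher number from compound 2 to compound 3 (0.44 log units; beyond the scatter) and nitro in place of chloro gives a 15-fold higher number from compound 1 to compound 3 (1.18 log units; beyond the scatter) at this position, on an aromatic carbon para to a large group. Both steps are beyond the scatter, so the position remains sensitive to the group it carries. Among these three compounds, the order runs from chloro through methoxy to nitro.

From the compounds shown here alone, whether an amine or a methyl group here would stand nearer chloro or nitro stays open. No measurement at hand accounts for this order.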